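A few compounds are considered here, and "the series" means these few. Any claim that something is new, unique, unknown or untested is made for them only; others in the source may bear on it.

Measured so far, in a functional assay on CRL2813 cells (Homo sapiens) for cytotoxicity, read by sulforhodamine B assay, with a stated time of 5 days; a higher number here means a weaker inhibitor, a lower number a stronger inhibitor:
compound 1 `COc1cccc(NC(=O)N[C@H]2CC[C@H](Oc3ccc(F)cc3)CC2)c1` gives 14000 nM
compound 2 `COC(=O)c1cccc(NC(=O)N[C@H]2CC[C@H](Oc3ccc(F)cc3)CC2)c1` gives 9200 nM
compound 3 `COc1ccc(NC(=O)N[C@H]2CC[C@H](Oc3ccc(F)cc3)CC2)cc1` gives > 20000 nM, which is a limit of this assay and not a number.

Compound 1 and compound 2 share a core and differ in one place, (methoxycarbonyl in place of methoxy on an aromatic carbon). The step is a 1.5-fold lower number from compound 1 to compound 2 (0.18 log units; within the scatter). Compound 1 and compound 3 are built from the same atoms joined differently, (4-methoxyphenyl in place of 3-methoxyphenyl on an amide-type nitrogen); the step is an at least 1.4-fold higher number from compound 1 to compound 3 (0.15 log units; that floor lies within the scatter), and for compound 3 only a limit is known, (the limit of > 20000 nM in this assay, at which 1 of the 3 values shown sits).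

Compound 4 `COC(=O)c1ccc(NC(=O)N[C@H]2CC[C@H](Oc3ccc(F)cc3)CC2)cc1` is not yet measured. It stands to compound 3 as compound 2 stands to compound 1, (methoxycarbonyl in place of methoxy on an aromatic carbon). The two places are not the same: in the pair compound 1 to compound 2 the change sits meta to a large group, in the pair compound 3 to compound 4 it sits para to a large group, so this is the same kind of change rather than the same change.

For compound 4 the step is expected to resemble the earlier one: an at least 1.1-fold lower number from compound 3 to compound 4 (0.04 log units; that floor lies within the scatter) beside a 1.5-fold lower number from compound 1 to compound 2 (0.18 log units; within the scatter), resting on compound 3 at > 20000 nM and on the small size of that earlier step. Since compound 3 is only a limit, compound 4 may well also come back as a limit. The expected value for compound 4 in this assay is 18000 nM, within a range from 9000 nM to 40000 nM.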

Compound 4, half-maximal inhibitory concentration: 11600 nM
Beside the measured number, compound 4's estimate is 1.6-fold (0.19 log units) above it, within the range that was stated.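

In this assay, methoxycarbonyl in place of methoxy on an aromatic carbon, para to a large group, gives an at least 1.7-fold lower number from compound 3 to compound 4 (0.23 log units; that floor lies within the scatter), and set beside the same change on the other core, the comparison stands as follows: the same change on two cores in this assay, a 1.5-fold lower number (0.18 log units; within the scatter) from compound 1 to compound 2 and an at least 1.7-fold lower number (0.23 log units; that floor lies within the scatter) from compound 3 to compound 4; the limit leaves it open whether they differ

Compound 3 is known only as a limit, > 20000 nM, so the true size of its step stays unknown and could lie well past the floor that is printed: the limit of > 20000 nM in this assay, at which 1 of the 4 values shown sits.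

The two steps therefore show that the change gives no conflict between the two cores, with a lower number in each case, but neither step is established beyond the scatter, so they do not show that the change carries over as a real gain, or with a fixed size, from one core to the other.

Left open is whether a carboxylic acid or a primary amide in the place of methoxycarbonyl would give a step beyond the scatter on either core. Also open, from the compounds shown here alone, is whether the same change would behave alike if the fluorine on the other aromatic ring gave way to chlorine or a nitrile.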